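A few compounds are considered here, and "the series" means these few. Any claim that something is new, unique, unknown or untested is made for them only; others in the source may bear on it.

Of the compounds shown here, two have so far been measured in a functional assay on CHO-K1 cells for antagonist activity at adenosine receptor A1 (Homo sapiens), read by a beta-galactosidase reporter and cAMP accumulation, with stated times of 15 min and 6 h; on this read-out higher numbers stand for weaker inhibition and lower numbers for stronger inhibition. Compound 1 `COc1ccccc1Cc1cc2c(N)nc(-c3ccc(C)o3)nc2s1` gives 122 nM, and compound 2 `Nc1nc(C2CCCO2)nc2sc(Cc3ccccc3)cc12` gives 2950 nM. Compound 2 therefore stands at the higher of the two numbers, the weaker inhibitor of the pair, and its distance from compound 1 lies well beyond the usual scatter of repeated measurements. Compound 3 `Nc1nc(-c2ccccc2)nc2sc(Cc3ccccc3)cc12` has not yet been measured. It differs from compound 2 in a single place: phenyl in place of oxolan-2-yl on an aromatic carbon. Within the data shown here, no measured pair of compounds shows this exact exchange, so its effect in this assay cannot be read off directly; the two measured values only show that a change in that part of the molecule can move the number a long way. The step from compound 2 to compound 3 is expected to be a moderate one toward stronger inhibition, a 7.4-fold lower number from compound 2 to compound 3 (0.87 log units; beyond the scatter). Compound 3 is estimated at 400 nM, within a range from 80 nM to 2000 nM.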

Compound 3, inhibition constant: 151 nM
For compound 3 the middle estimate is 2.6-fold (0.42 log units) above the measured one; the range from low to high includes it.
By their numbers in this assay, from the lowest: compounds 1 and 3 (each within the scatter of the next); then compound 2.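

In this assay, the aromatic carbon between two ring nitrogen atoms now proves to be a sensitive position: with the rest of the molecule unchanged, phenyl in place of oxolan-2-yl gives a 20-fold lower number from compound 2 to compound 3 (1.29 log units; beyond the scatter), a large step toward stronger inhibition. The earlier pair differed in more than one place, so it could not tie any shift to this position alone. This exchange replaces a non-aromatic ring holding one oxygen with an aromatic ring of carbon only, but no available measurement explains the step.

The compounds shown leave open whether a cyclohexyl ring, a pyridyl ring or a simple amine at this carbon would behave like phenyl or like oxolan-2-yl. They also leave open whether the same exchange would give a similar step with a different group elsewhere on the core.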